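This account rests on a few compounds, and the source may have more. Where it says the series, first, only, none or still open, it means among the compounds named here.

The measured compounds:

Compound 1 `COc1cc(/C=C/C(=O)c2cccc(-n3cc(-c4ccc(Cl)cc4)[nH]c3=O)c2)ccc1O` gives 2230 nM in a functional assay on U-251 cells (Homo sapiens) for inhibition; on this read-out higher numbers stand for weaker inhibition of growth and lower numbers for stronger inhibition of growth.
Compound 2 `COc1ccc(-c2cn(-c3cccc(C(=O)/C=C/c4cc(OC)c(OC)c(OC)c4)c3)c(=O)[nH]2)cc1` gives 880 nM in this assay.

Compound 2 holds the lowest of the two numbers; its nearest neighbour is compound 1, whose number is higher by a margin beyond the usual scatter. For the measured compounds named here, compound 1 and compound 2 differ in more than one place, so no single step can be drawn between them and their gap is read only as what the two values show.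

Compound 3 `COc1ccc(-c2cn(-c3cccc(C(=O)/C=C/c4ccc(O)c(OC)c4)c3)c(=O)[nH]2)cc1` has not yet been measured in this assay. It differs from compound 2 in one place: 4-hydroxy-3-methoxyphenyl in place of 3,4,5-trimethoxyphenyl on a double-bonded chain carbon bound to a double-bonded chain carbon. Going by the values given here, no step between measured compounds that differ in one place is available to calibrate this change. The group that enters in compound 3 is the group that compound 1 carries on its double-bonded chain, and compound 1 gives the higher number of the two in this assay at 2230 nM. A moderate step toward weaker inhibition of growth is therefore expected, a 1.8-fold higher number from compound 2 to compound 3 (0.26 log units; within the scatter). For compound 3 the expected value in this assay is 1600 nM, with a range from 700 nM to 3600 nM.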

Compound 3, concentration for 50% growth inhibition: 3450 nM
For compound 3 the middle estimate is 2.2-fold (0.33 log units) below the measured one, and the stated range covers the measured number.
By their numbers in this assay, from the lowest: compound 2; then compounds 1 and 3 (each within the scatter of the next).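

In this assay the change from 3,4,5-trimethoxyphenyl to 4-hydroxy-3-methoxyphenyl on a double-bonded chain carbon bound to a double-bonded chain carbon now has a measured size of a 3.9-fold higher number from compound 2 to compound 3 (0.59 log units; beyond the scatter) and points toward weaker inhibition of growth, which gives this position its first single-place step. The other new step, methoxy in place of chloro on an aromatic carbon, is a 1.5-fold higher number from compound 1 to compound 3 (0.19 log units; within the scatter) and so, with 4-hydroxy-3-methoxyphenyl on the chain, this exchange does not separate the two compounds beyond the scatter. No measurement is at hand that would explain either step.

The compounds shown leave open which part of the first change carries the step, as the hydroxy group enters while the methoxy groups change in the same exchange; a 3,4-dimethoxyphenyl or a 4-hydroxy-3,5-dimethoxyphenyl group at this place would pull these apart. They also leave open whether the methoxy and chloro exchange stays as small with 3,4,5-trimethoxyphenyl on the chain, and how an amine on that ring would read out here.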